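This account rests on a few compounds, and the source may have more. Where it says the series, first, only, none or still open, it means among the compounds named here.

In a functional assay on MCF7 cells (Homo sapiens) for antiproliferative activity, read by MTT assay, with a stated time of 24 h (on this read-out higher numbers stand for weaker inhibition and lower numbers for stronger inhibition), compound 1 `CCn1c(C(=O)N[C@H](CO)C(C)C)ccc1C(CC)(CC)c1ccc(OCS(=O)(=O)c2ccccc2)c(C)c1` gives 25500 nM. In the same read-out compound 2 `CCn1c(C(=O)NCC(=O)O)ccc1C(CC)(CC)c1ccc(OCS(=O)(=O)c2ccccc2)c(C)c1` gives 33100 nM. Within the data shown here, compound 2 thus stands level with compound 1, the only other measured compound, and the two values lie within the scatter of each other.

Compound 3 `CCn1c(C(=O)N[C@@H](C(=O)O)C(C)C)ccc1C(CC)(CC)c1ccc(OCS(=O)(=O)c2ccccc2)c(C)c1` is reached from compound 2 by one change: isopropyl in place of hydrogen on a saturated chain carbon bound to an amide-type nitrogen and a carbonyl carbon. In words, isopropyl replaces hydrogen on a saturated chain carbon bound to an amide-type nitrogen and a carbonyl carbon, turning carboxymethyl into 1-carboxy-2-methylpropyl.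

Among the measured compounds shown here, one measured step bears on this change: a 1.3-fold higher number from compound 1 to compound 2 (0.11 log units; within the scatter). That step puts carboxymethyl in place of 1-(hydroxymethyl)-2-methylpropyl on the amide-type nitrogen, so it is only an indirect guide, as the end group differs as well. For the measured compounds named here, no measured pair isolates isopropyl against hydrogen. With that single step as the guide, no change beyond the scatter is expected in this assay, in either direction.

The expected step is a 1.1-fold lower number from compound 2 to compound 3 (0.04 log units; within the scatter). For compound 3 the estimated value is 30000 nM, with an expected range of 14000 nM to 60000 nM.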

Compound 3, half-maximal inhibitory concentration: 44700 nM
Compound 3: the middle estimate sits 1.5-fold (0.17 log units) below what was measured, and the stated range covers the measured number.
By their numbers in this assay, from the lowest: compounds 1, 2 and 3 (each within the scatter of the next).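

In this assay, among these compounds, the step for isopropyl in place of hydrogen on the saturated chain carbon bound to an amide-type nitrogen and a carbonyl carbon is a 1.4-fold higher number from compound 2 to compound 3 (0.13 log units; within the scatter), the first direct reading of this change at this place, and it stays within the scatter. The other new step, a 1.8-fold higher number from compound 1 to compound 3 (0.24 log units; within the scatter), compares 1-carboxy-2-methylpropyl with 1-(hydroxymethyl)-2-methylpropyl on the amide-type nitrogen; it isolates the end group with the isopropyl present on both sides, and it too stays within the scatter, so neither change separates the three compounds in this assay. No measurement at hand accounts for either step.

Still open, as far as these compounds go, is whether another group on this chain carbon, such as methyl, a longer chain or benzyl, or a primary amide or methyl ester in place of the carboxy group, would give a step beyond the scatter. Also open, from the compounds shown here alone, is whether an amine at the chain end would leave the number within the scatter of compound 3, and whether these steps hold in other cell lines.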